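The compounds below may be only part of what the source reports. "The series", "measured", "known", "first", "only" and "open" are said of these compounds alone.

Measured so far:
compound 1, `COc1cc2c(Oc3ccc(NC(=O)c4nn(-c5ccccc5C(F)(F)F)c(=O)cc4C)cc3F)ccnc2cc1OCCCN1CCCC1`: 130 nM
compound 2, `COc1cc2c(Oc3ccc(NC(=O)c4nn(-c5ccccc5C(F)(F)F)c(=O)cc4C)cc3F)ccnc2cc1OCCCN1CCC(C)CC1`: 160 nM

In a functional assay on A549 cells (Homo sapiens) for inhibition, read by MTT assay, with a stated time of 72 h (a higher number here means a weaker inhibitor, a lower number a stronger inhibitor), compound 1 gives the lowest of the two numbers, but its neighbour compound 2 sits within the scatter: a 1.2-fold higher number from compound 1 to compound 2 (0.09 log units; within the scatter). That single step swaps only the amine at the end of the chain, so it says nothing about the part of the molecule that changes next.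

Compound 3, `COc1ccc(-n2nc(C(=O)Nc3ccc(Oc4ccnc5cc(OCCCN6CCCC6)c(OC)cc45)c(F)c3)c(C)cc2=O)cc1`, has not yet been measured in this assay. It differs from compound 1 in one place: 4-methoxyphenyl in place of 2-(trifluoromethyl)phenyl on an aromatic nitrogen. Within the data shown here, no measured pair in this set alters the group on that aromatic nitrogen, so there is no step to lean on; the expectation rests only on compound 1 at 130 nM and on the change itself, with a modest weakening judged likely but far from certain. Compound 3 is therefore expected to give about 220 nM, between 70 nM and 700 nM, an estimated step of a 1.7-fold higher number from compound 1 to compound 3 (0.23 log units; within the scatter).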

Compound 3, half-maximal inhibitory concentration: 2770 nM
The estimate for compound 3 lay 13-fold (1.10 log units) below the measured number; the whole stated range lies below it.
By their numbers in this assay, from the lowest: compounds 1 and 2 (each within the scatter of the next); then compound 3.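

In this assay, the group on the aromatic nitrogen proves far more sensitive than anything the amine swap suggested: 4-methoxyphenyl in place of 2-(trifluoromethyl)phenyl gives a 21-fold higher number from compound 1 to compound 3 (1.33 log units; beyond the scatter), while the change at the end of the chain gave only a 1.2-fold higher number from compound 1 to compound 2 (0.09 log units; within the scatter). This single step changes both the substituent and where it sits on the phenyl ring, and it does not separate those two changes. No measurement at hand accounts for the loss.

From the compounds shown here alone, it remains open whether 2-methoxyphenyl or 4-(trifluoromethyl)phenyl on that nitrogen would fall nearer compound 1 or compound 3, and where unsubstituted phenyl would stand. Also open, going by these compounds, is whether 4-methylpiperidin-1-yl and pyrrolidin-1-yl would stay as close together with 4-methoxyphenyl on the nitrogen.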